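Two benzoxazolone analogues and a chlorophenyl swap

This account rests on a few compounds, and the source may have more. Where it says the series, first, only, none or still open, it means among the compounds named here.

Measured compounds:
compound 1 `O=c1oc2ccc(F)cc2n1Cc1ccc(Cl)cc1` — 80800 nM
compound 2 `O=c1oc2ccc([N+](=O)[O-])cc2n1Cc1cccc(F)c1` — 99800 nM

In an assay on HeLa cells for inhibition of Indoleamine 2,3-dioxygenase 1 (Homo sapiens), with a stated time of 24 h (on this read-out higher numbers stand for weaker inhibition and lower numbers for stronger inhibition), compound 1 gives 80800 nM and compound 2 gives 99800 nM. Compound 2 holds the higher of the two readings, yet its difference from compound 1 is within the scatter, so the two compounds cannot be told apart in this assay. Compound 3 `O=c1oc2ccc([N+](=O)[O-])cc2n1Cc1ccc(Cl)cc1` carries 4-chlorophenyl in place of 3-fluorophenyl on a saturated chain carbon bound to an aromatic nitrogen. Going by the values given here, no step between measured compounds is available to guide this change; compound 1 and compound 2 differ in two places at once. The step from compound 2 to compound 3 is therefore expected to be small, a 1.2-fold lower number from compound 2 to compound 3 (0.10 log units; within the scatter), not clearly beyond the scatter. Compound 3 is estimated at 80000 nM, within 35000 nM to 180000 nM.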

Compound 3, half-maximal inhibitory concentration: 99400 nM
Compound 3: middle estimate off by 1.2-fold (0.09 log units), on the low side; the range from low to high includes it.
By their numbers in this assay, from the lowest: compounds 1, 3 and 2 (each within the scatter of the next).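

In this assay the change to 4-chlorophenyl on a saturated chain carbon bound to an aromatic nitrogen gives a 1.0-fold lower number from compound 2 to compound 3 (0.00 log units; within the scatter) and the change to nitro in place of fluoro on an aromatic carbon gives a 1.2-fold higher number from compound 1 to compound 3 (0.09 log units; within the scatter) and both lie within the scatter. Each place can now be read alone, which the earlier pair, differing in two places at once, did not allow, and neither change separates the compounds. Nothing at hand offers an explanation for this result.

On these data alone, whether an amine or a carboxylic acid on that aromatic carbon would move the number beyond the scatter stays open. So does the effect of a longer chain in place of the 4-chlorophenyl.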